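The compounds below may be only part of what the source reports. "The series", "measured", "known", "first", "only" and "open" are said of these compounds alone.

Measured so far:
compound 1, `COc1cc(/C=C/C(=O)Nc2ccc3c(c2)COC3=O)cc(OC)c1OC`: 1730 nM
compound 2, `Cc1ccccc1NC(=O)Nc1ccc2c(c1)COC2=O`: 900 nM

Both were tested in a functional assay on cells (T-cell, Mus musculus) for inhibition; a higher number here means a weaker inhibitor, a lower number a stronger inhibitor. In this assay compound 2 gives 900 nM, and in the same assay compound 1 gives 1730 nM; the gap between the two lies within the usual scatter, so neither can be placed ahead of the other. Compound 3, `O=C(Nc1ccc2c(c1)COC2=O)NC1CCCCC1`, has not yet been measured. It differs from compound 2 in one place: cyclohexyl in place of 2-methylphenyl on an amide-type nitrogen. Among the measured compounds shown here, no step between measured compounds covers such a change, so the step expected here, a 1.7-fold higher number from compound 2 to compound 3 (0.22 log units; within the scatter), is judged small, a mild weakening that may not exceed the scatter. Compound 3 is therefore expected to give about 1500 nM in this assay, in a range from 500 nM to 5000 nM.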

Compound 3, half-maximal inhibitory concentration: 12700 nM
Beside the measured number, compound 3's estimate is 8.5-fold (0.93 log units) below it; measured number outside the range, above it.
By their numbers in this assay, from the lowest: compounds 2 and 1 (each within the scatter of the next); then compound 3.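

Among the compounds shown here, at this amide-type nitrogen in this assay, the group matters far more than the earlier compounds could show: cyclohexyl in place of 2-methylphenyl gives a 14-fold higher number from compound 2 to compound 3 (1.15 log units; beyond the scatter). Here, then, the non-aromatic ring does not stand in for the aromatic one without a clear loss of inhibition. Nothing available accounts for this loss. The compounds shown leave open whether the aromatic ring or its methyl carries the difference, and how a plain phenyl or a 2-methoxyphenyl group would compare at this nitrogen.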